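Methyl on the aromatic carbon of compound 1

The source may hold more compounds than are shown below. What is called first, only, known or untested is meant among the compounds shown, and "the series" means these compounds.

Measured in an ADME assay on J774.A1 cells (Mus musculus) for cytotoxicity, read by MTT assay, with a stated time of 72 h; a lower number here means that less compound is needed, a higher number that more compound is needed for the effect:
- compound 1 `CC(C)Nc1nc(NCc2ccco2)c2ccccc2n1`: 17000 nM
- compound 2 `CCOC(=O)CNc1nc(NC(C)C)nc2ccccc12`: > 33000 nM (a limit)

In this assay, among the compounds with values here, compound 1 gives 17000 nM, the only actual number so far. Compound 2 gives > 33000 nM, which is a limit of the assay and not a number (the limit of > 33000 nM in this assay, at which 1 of the 2 values shown sits).

Compound 3 `Cc1ccc2c(NCc3ccco3)nc(NC(C)C)nc2c1` has not yet been measured. It differs from compound 1 by methyl in place of hydrogen on an aromatic carbon.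

Within the data shown here, the only measured step is an at least 1.9-fold higher number from compound 1 to compound 2 (0.28 log units; that floor lies within the scatter). That step swaps furan-2-yl for ethoxycarbonyl and leaves the aromatic carbon untouched, so it says little about the new methyl. Among the measured compounds shown here, no measured step covers a change of this kind, and with no evidence for a shift in either direction, no step beyond the scatter is expected in this assay.

The expected step is a 1.1-fold lower number from compound 1 to compound 3 (0.03 log units; within the scatter). For compound 3 the estimated value is 16000 nM, with an expected range from 7500 nM to 33000 nM.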

Compound 3, half-maximal effective concentration: > 33000 nM
Compound 3 was reported as a limit; the forecaster's own chance of this, stated with the estimate: 15%; middle value at least 2.0-fold (0.31 log units) away from the limit.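

Within the data shown here, the earlier step concerned only the chain bound to the ring nitrogen, whereas this one gives the first reading on the aromatic carbon, meta to a fused ring and para to a fused ring, with furan-2-yl kept in place: in this assay, methyl in place of hydrogen gives an at least 1.9-fold higher number from compound 1 to compound 3 (0.28 log units; that floor lies within the scatter). Compound 3 gives > 33000 nM, which is a limit of the assay and not a number, so this change yields no actual value and no shift beyond the scatter can be claimed. A single added methyl on the shared core is nonetheless enough to leave the series with only one actual number, and the limit now holds most of the data: the limit of > 33000 nM in this assay, at which 2 of the 3 values shown sit.

How far compound 3 really lies from compound 1 stays unresolved, as does whether the direction of this step would hold on a scale without a limit. Also open, as far as these compounds go, is what a methoxy group, a chlorine atom or an amine would give on the same aromatic carbon, and whether a methyl on another carbon of the same ring would read the same way.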